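Benzyloxy to dimethylamino on compound 3

The compounds below may be only part of what the source reports. "The series", "measured", "known", "first", "only" and "open" are said of these compounds alone.

Three compounds have numbers in a functional assay for inhibition, with Homo sapiens as the target; on this read-out lower numbers stand for stronger inhibition and higher numbers for weaker inhibition: compound 1 `COc1cc(OC)c(C(=O)/C=C/c2ccncc2)c(OC)c1` gives 592 nM, compound 2 `COc1cccc(OC)c1C(=O)/C=C/c1ccccc1` gives 1150 nM, and compound 3 `O=C(/C=C/c1ccccc1)c1ccccc1OCc1ccccc1` gives 2230 nM. Compound 3 stands within the scatter of compound 2, while its number lies above that of compound 1 by more than the scatter. No two of these compounds differ in one place only, so no measured step bears directly on the change at hand.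

Compound 4 `CN(C)c1ccccc1C(=O)/C=C/c1ccccc1` has dimethylamino in place of benzyloxy on an aromatic carbon, ortho to a large group: dimethylamino in place of benzyloxy on an aromatic carbon. No shift beyond the scatter is expected in this assay, in either direction. This expectation rests only on the spread of the measured values, from compound 1 at 592 nM to compound 3 at 2230 nM. The estimated change is a 1.2-fold lower number from compound 3 to compound 4 (0.09 log units; within the scatter), expected to stay within the scatter. For compound 4 the estimate is 1800 nM, with an expected range of 600 nM to 5500 nM.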

Compound 4, half-maximal inhibitory concentration: 1770 nM
Estimate against measurement, compound 4: 1.0-fold (0.01 log units) above; measured number inside the range.
By their numbers in this assay, from the lowest: compounds 1, 2, 4 and 3 (each within the scatter of the next, the first and the last beyond it).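

In this assay, dimethylamino in place of benzyloxy on an aromatic carbon, ortho to a large group, gives a 1.3-fold lower number from compound 3 to compound 4 (0.10 log units; within the scatter). Within the data shown here, this is the first comparison that differs in one place only, and it shows that the aromatic ring of the benzyloxy group can leave this position without a shift beyond the scatter, while the entering group has no ring. No available evidence bears on why the number holds across this change.

The compounds shown leave open whether a carboxylic acid, a primary amine or a longer alkoxy chain in this position would also stay within the scatter of compound 3. On these data alone, it also remains open whether dimethylamino in place of benzyloxy would give a similar step on the core of compound 1.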